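From Dimethylamino to Imidazol-1-yl on the Side Chain

This account rests on a few compounds, and the source may have more. Where it says the series, first, only, none or still open, it means among the compounds named here.

Three compounds were measured in a toxicity assay on HEK-293T cells (Homo sapiens) for cytotoxicity, read by MTT assay, with a stated time of 72 h; on this read-out lower numbers stand for stronger inhibition and higher numbers for weaker inhibition:

compound 1 `O=C1c2c[n+]([O-])c3ccccc3c2C(=O)c2c1c1ccccc1n2Cc1cn([C@@H]2C[C@H](O)[C@@H](CO)O2)nn1`: 820 nM
compound 2 `CN(C)CCCCn1c2c(c3ccccc31)C(=O)c1c[n+]([O-])c3ccccc3c1C2=O`: 520 nM
compound 3 `O=C1c2c[n+]([O-])c3ccccc3c2C(=O)c2c1c1ccccc1n2Cc1cn([C@@H]2O[C@H](CO)[C@@H](O)[C@H](O)[C@H]2O)nn1`: 940 nM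

Compound 2 gives the lowest of these three numbers, yet its gaps to compound 1 and to compound 3 both lie within the usual scatter, so the three cannot be told apart on these data. Compound 4 `O=C1c2c[n+]([O-])c3ccccc3c2C(=O)c2c1c1ccccc1n2CCCCn1ccnc1` is unmeasured; its difference from compound 2 is 1H-imidazol-1-yl in place of dimethylamino on a saturated chain carbon, four bonds along the chain from an aromatic nitrogen.

Within the data shown here, only one measured step exists, a 1.1-fold higher number from compound 1 to compound 3 (0.06 log units; within the scatter), and it concerns a sugar on an aromatic nitrogen in the side chain of compound 1, not the chain end that changes here. Among the measured compounds shown here, no measured step therefore bears on the change from dimethylamino to 1H-imidazol-1-yl, and nothing in the data points to a move in either direction. The estimate for compound 4 is accordingly anchored on compound 2, with the step of a 1.2-fold higher number from compound 2 to compound 4 (0.06 log units; within the scatter) expected to stay within the scatter. Compound 4 is thus estimated at 600 nM in this assay, with a range from 250 nM to 1500 nM.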

Compound 4, half-maximal inhibitory concentration: 280 nM
Compound 4: the middle estimate sits 2.1-fold (0.33 log units) above what was measured, and the stated range covers the measured number.
By their numbers in this assay, from the lowest: compounds 4, 2, 1 and 3 (each within the scatter of the next, the first and the last beyond it).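

In this assay, among these compounds, the step at the chain end reads a 1.9-fold lower number from compound 2 to compound 4 (0.27 log units; within the scatter), the first measured step at this position, on a saturated chain carbon, four bonds along the chain from an aromatic nitrogen. Dimethylamino and 1H-imidazol-1-yl therefore cannot be told apart on these data, although the change replaces an open group with one five-membered aromatic ring. No supporting measurement is available to interpret this result.

The compounds shown leave open whether a different end group on the same chain, such as a morpholine or a carboxylic acid, would give a step beyond the scatter in this assay. They also leave open how a longer chain carrying 1H-imidazol-1-yl or dimethylamino would read.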